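Swapping the aryl group on the ring oxygen of compound 3

A few compounds are considered here, and "the series" means these few. Any claim that something is new, unique, unknown or untested is made for them only; others in the source may bear on it.

Measured compounds:
compound 1 `COc1cccc(CNCCCNc2ccnc3cc(C4CCCCC4)ccc23)c1O` gives 4200 nM
compound 2 `COc1cccc(CNCCCNc2ccnc3cc(Oc4ccc(F)cc4)ccc23)c1O` gives 14500 nM
compound 3 `COc1ccccc1Oc1ccc2c(NCCCNCc3cccc(OC)c3O)ccnc2c1` gives 14500 nM

In a physicochemical assay for solubility, with a stated time of 18 h, at pH 7.4 (a higher number here means a more soluble compound, a lower number a less soluble compound), compound 3 stands level with compound 2 at the digits shown, and the two share the highest numbers of the three; compound 1 sits furthest away, as seen in a 3.5-fold higher number from compound 1 to compound 3 (0.54 log units; beyond the scatter). Compound 4 `COc1cccc(CNCCCNc2ccnc3cc(Oc4ccc(Cl)cc4)ccc23)c1O` has not yet been measured. The change from compound 3 to compound 4 is 4-chlorophenyl in place of 2-methoxyphenyl on an oxygen on an aromatic ring.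

One measured step speaks most directly to this change: no change at the digits printed from compound 2 to compound 3 (within the scatter), where one aryl group on the ring oxygen was exchanged for another and the number did not move. The two larger steps, a 3.5-fold higher number from compound 1 to compound 2 (0.54 log units; beyond the scatter) and a 3.5-fold higher number from compound 1 to compound 3 (0.54 log units; beyond the scatter), concern a different exchange, a carbon ring replaced by a phenoxy group, and so say little about compound 4. On this basis a step of no more than the scatter is expected in this assay, namely a 1.3-fold lower number from compound 3 to compound 4 (0.12 log units; within the scatter). Compound 4 is therefore estimated at 11000 nM, with a likely range from 4500 nM to 25000 nM.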

Compound 4, solubility: 14500 nM
Estimate against measurement, compound 4: 1.3-fold (0.12 log units) below; the range from low to high includes it.
By their numbers in this assay, from the lowest: compound 1; then compounds 2, 3 and 4 (each within the scatter of the next).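

In this assay the new group gives no change at the digits printed from compound 3 to compound 4 (within the scatter) and the exchange of halogen gives no change at the digits printed from compound 2 to compound 4 (within the scatter), so this position now tolerates a third aryl group on the oxygen, one with a chlorine and without the hydrogen-bond acceptor of 2-methoxyphenyl, while the number stays level. The gap to the cyclohexyl compound also holds, at a 3.5-fold higher number from compound 1 to compound 4 (0.54 log units; beyond the scatter), so in the compounds shown it separates all three phenoxy groups from cyclohexyl rather than one aryl group from another. Nothing measured here explains why these numbers coincide.

All three aryl groups on this oxygen are built only from carbon, hydrogen, halogen or ether oxygen. On these data alone, whether an amine or a carboxylic acid on that ring would shift the number remains open, as does the effect of replacing the aryl group with a short alkyl chain.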